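A few compounds are considered here, and "the series" means these few. Any claim that something is new, unique, unknown or untested is made for them only; others in the source may bear on it.

The series rests on a shared core, seen in compound 1 `COc1ccc(C(=O)c2cc(OC)c(OC)c(OC)c2)cc1N`. In a functional assay on COLO 205 cells (Homo sapiens) for cytotoxicity, read by MTT assay, with a stated time of 72 h (on this read-out higher numbers stand for weaker inhibition and lower numbers for stronger inhibition), compound 1 gives 200 nM. Going by the values given here, compound 2 `COc1cccc(/C=C/C(=O)Nc2cc(C(=O)c3cc(OC)c(OC)c(OC)c3)ccc2OC)c1` carries a cinnamoyl amide on the same core, and in this assay compound 2 gives 5100 nM, the highest of the two numbers recorded; the gap to compound 1 lies well beyond the usual scatter of repeated measurements, and no single-point step between the two is set out.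

Compound 3 `COc1ccc(C(=O)c2cc(OC)c(OC)c(OC)c2)cc1NC(=O)/C=C/c1cccc(OC(F)(F)F)c1` has not yet been measured in this assay. It differs from compound 2 in one place: trifluoromethyl in place of methyl on an oxygen on an aromatic ring. Read one bond further out, the change is methoxy to trifluoromethoxy, or 3-methoxyphenyl to 3-(trifluoromethoxy)phenyl.

Among the compounds with values here, nothing among the measured compounds shows how such an exchange on the outer ring plays out here. The expected step from compound 2 to compound 3 is therefore modest, a 1.1-fold lower number from compound 2 to compound 3 (0.05 log units; within the scatter), and may well fall within the scatter. For compound 3 the estimate in this assay is 4500 nM, with a range from 1500 nM to 13000 nM.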

Compound 3, half-maximal inhibitory concentration: 7900 nM
Beside the measured number, compound 3's estimate is 1.8-fold (0.24 log units) below it; the measured number falls inside the stated range.
By their numbers in this assay, from the lowest: compound 1; then compounds 2 and 3 (each within the scatter of the next).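

In this assay, going by these compounds alone, the exchange of methoxy for trifluoromethoxy on the outer ring gives the first direct reading for this position (a 1.5-fold higher number from compound 2 to compound 3 (0.19 log units; within the scatter)). Three added fluorine atoms on that oxygen therefore leave the number indistinguishable from that of the methoxy compound, and this single exchange gives no sign that the assay separates the two groups. No measurement at hand offers an explanation for this result or links it to any property of either group.

What the compounds shown leave open is whether any other group at this place would produce a step beyond the scatter, for instance a hydroxyl, an amine, a carboxylic acid or a longer alkoxy chain such as butoxy in place of the methoxy. They also leave open whether the same exchange of methyl for trifluoromethyl on an oxygen would read the same way on the trimethoxyphenyl part of the shared core, since this one pair speaks only for the 3-methoxyphenyl to 3-(trifluoromethoxy)phenyl change.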